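The compounds below may be only part of what the source reports. "The series", "measured", "known", "first", "only" and "open" are said of these compounds alone.

Working notes on the series. Three analogues built on a common core have been run in a functional assay on Hs-578T cells (Homo sapiens) for cytotoxicity, read by sulforhodamine B assay, with a stated time of 48 h (a lower number here means a stronger inhibitor of growth, a higher number a weaker inhibitor of growth), so far. Compound 1 `ClCc1cccc(Cn2cnc3c(Cl)nc(Cl)nc32)c1` gives 4360 nM in this assay. Compound 3 `ClCc1ccccc1Cn1cnc2c(Cl)nc(Cl)nc21` gives 3540 nM in this assay, and compound 2 `ClCc1ccccc1Cn1cnc2ncnc(Cl)c21` gives 6020 nM in this assay. All three numbers lie within the usual scatter of one another, so no ranking among compounds 1, 2 and 3 can be drawn from them.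

The next compound, compound 4 `Nc1nc(Cl)c2ncn(Cc3cccc(CCl)c3)c2n1`, differs from compound 1 in one place: amino in place of chloro on an aromatic carbon. Going by the values given here, no measured pair in the set shows this change, so no step size can be read from the data. The expectation is that the step from compound 1 to compound 4 stays near the scatter, with a 1.1-fold higher number from compound 1 to compound 4 (0.06 log units; within the scatter). Compound 4 is expected to give about 5000 nM in this assay, within 1500 nM to 17000 nM.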

Compound 4, concentration for total growth inhibition: 60300 nM
For compound 4 the middle estimate is 12-fold (1.08 log units) below the measured one; measured number above the stated range.
By their numbers in this assay, from the lowest: compounds 3, 1 and 2 (each within the scatter of the next); then compound 4.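

On the aromatic carbon between two ring nitrogen atoms, amino in place of chloro gives a 14-fold higher number from compound 1 to compound 4 (1.14 log units; beyond the scatter) in this assay, so this change makes a weaker inhibitor of growth. Going by these compounds alone, the earlier compounds allowed no ranking, and this is the first step to lie beyond the scatter, which shows that the series can respond strongly to a change at this position.

From the compounds shown here alone, whether a methylamino, hydroxy or methoxy group on this carbon would track chloro or amino stays open. No measurement shown bears on the cause of this step.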